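The source may hold more compounds than are shown below. What is called first, only, known or untested is meant among the compounds shown, and "the series" means these compounds.

Measured so far in an assay on isolated protein for inhibition of Ca2+/calmodulin-dependent protein kinase II (CaM kinase II) (Rattus norvegicus), tested at 30 uM; a lower number here means less inhibition, a higher number more inhibition at the concentration tested (going by the name of the read-out):
- compound 1 `CSc1ccc(-c2nc3c(Sc4ccccc4)ncnc3n2C)cc1` gives 0%
- compound 2 `Cn1c(-c2ccc([S+](C)[O-])cc2)nc2c(Sc3ccccc3)ncnc21` gives 8%

Compound 2 stands highest of these two numbers, but its nearest neighbour, compound 1, lies only a number 8 percentage points higher from compound 1 to compound 2 (within the scatter) away, so the two cannot be told apart. Compound 3 `Cn1c(-c2ccc(S(C)(=O)=O)cc2)nc2c(Sc3ccccc3)ncnc21` is the next member of the series. It differs from compound 2 in one place: a group of 4 heavy atoms (1 carbon, 2 oxygen, 1 sulfur; no ring) in place of a group of 3 heavy atoms (1 carbon, 1 oxygen, 1 sulfur; no ring), on an aromatic carbon. Among the measured compounds shown here, the only measured step that bears on this change is the one from compound 1 to compound 2, which also altered the same group on the same aromatic carbon and produced a number 8 percentage points higher from compound 1 to compound 2 (within the scatter). Since that step did not move the read-out beyond the scatter, the further change to compound 3 is expected to give a number 2 percentage points higher from compound 2 to compound 3 (within the scatter), that is, no step beyond the scatter in this assay. Compound 3 is therefore estimated at 10%, with a range from 0% to 25%.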

Compound 3, a percentage reported as inhibition, at one concentration (the size of the read-out at that concentration, not a potency): 8%
Compound 3: the middle estimate sits 2 percentage points above what was measured, within the range that was stated.
By their numbers in this assay, from the lowest: compounds 1, 2 and 3 (each within the scatter of the next).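

In this assay the swap of the group on this aromatic carbon for methylsulfonyl gives a small step (no change at the digits printed from compound 2 to compound 3 (within the scatter)), and the whole change from methylsulfanyl to methylsulfonyl also stays small (a number 8 percentage points higher from compound 1 to compound 3 (within the scatter)). Both steps are within the scatter, so the three sulfur-bearing groups at this position, para to a large group, cannot be told apart in this read-out at the single concentration tested, even with a second oxygen on the sulfur. No measurement is available that would explain this flat result.

The compounds shown leave open whether a group without sulfur at this position, such as an amine or a carboxylic acid, would move the number beyond the scatter. They also leave open whether a change elsewhere on the shared core would do so.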